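The source may hold more compounds than are shown below. What is called first, only, known or untested is meant among the compounds shown, and "the series" means these compounds.

Measured so far:
compound 1 `Cc1cc(C)nc(NS(=O)(=O)c2ccc(N3C(=O)/C(=C/c4coc5ccccc5c4=O)N=C3c3ccccc3)cc2)n1` — 99700 nM
compound 2 `Cc1cc(C)nc(NS(=O)(=O)c2ccc(N3C(=O)/C(=C/c4coc5ccccc5c4=O)N=C3c3ccc(Cl)cc3)cc2)n1` — 93900 nM

Both values come from a functional assay on MCF7 cells (Homo sapiens) for cytotoxicity, read by sulforhodamine B assay, with a stated time of 72 h; a higher number here means a weaker inhibitor, a lower number a stronger inhibitor. Compound 1 gives the highest of the two numbers; its nearest neighbour is compound 2, and the step of a 1.1-fold lower number from compound 1 to compound 2 (0.03 log units; within the scatter) is the only one available, a chloro in place of hydrogen on an aromatic carbon. The unmeasured compound 3 `O=C1/C(=C/c2coc3ccccc3c2=O)N=C(c2ccccc2)N1c1ccc(S(=O)(=O)Nc2ccccn2)cc1` differs from compound 1 by pyridin-2-yl in place of 4,6-dimethylpyrimidin-2-yl on a sulfonamide nitrogen. Among the measured compounds shown here, no measured step touches the sulfonamide nitrogen, so there is nothing to carry over from compound 2 to this change. With both measured numbers so close, the working expectation is a step of a 1.0-fold higher number from compound 1 to compound 3 (0.00 log units; within the scatter) that stays inside the scatter. Compound 3 is therefore estimated at 100000 nM, with a range of 40000 nM to 250000 nM.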

Compound 3, half-maximal inhibitory concentration: > 100000 nM
Compound 3 was reported as a limit; the forecaster's own chance of this, stated with the estimate: 25%; the middle value lies on the limit itself.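

For compound 3, the result in this assay is a limit and not a number: > 100000 nM. Among the compounds shown here, this gives the first information on the sulfonamide nitrogen, and it is one-sided: pyridin-2-yl in place of 4,6-dimethylpyrimidin-2-yl brings a number no lower from compound 1 to compound 3 (the limit leaves the size open), and the size of the step cannot be read. The end of the readable range is reached within this small set: the limit of > 100000 nM in this assay, at which 1 of the 3 values shown sits.

On these data alone, whether any group on the sulfonamide nitrogen can bring a clearly lower number stays open. A thiazol-2-yl or an acetyl group there would test this.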